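Thiomethyl substituent: benzothiophene to cyclohexyl

This account rests on a few compounds, and the source may have more. Where it says the series, first, only, none or still open, it means among the compounds named here.

The shared core carries a sulfur-linked methylene bearing a variable group and an amino-pyrazole arm. Compound 1 `Cc1cc(Nc2cc(-c3ccccc3)[nH]n2)n2nc(SCc3csc4ccccc34)nc2n1` carries (1-benzothiophen-3-yl)methyl on the sulfur; in a functional assay on PC-9 cells (Homo sapiens) for inhibition, read by MTT assay, with a stated time of 72 h (on this read-out lower numbers stand for stronger inhibition and higher numbers for weaker inhibition), compound 1 gives 4420 nM. Compound 2 `Cc1cc(Nc2cc(-c3cccs3)[nH]n2)n2nc(SCc3ccc(Br)cc3)nc2n1`, with a thiophene on the pyrazole and a bromobenzyl on the sulfur, gives 4890 nM in this assay, which sits within the scatter of compound 1, so the two cannot be ordered. Compound 1 thus holds the lowest of the two numbers shown, but not a distinguishable one. Compound 3 `Cc1ccc(Cn2ccc(Nc3cc(C)nc4nc(SCc5ccc(Br)cc5)nn34)n2)cc1`, in which the pyrazole nitrogen is substituted, reaches only the limit of this assay, > 50000 nM; the value is a limit and not a number, as noted in the limit of > 50000 nM in this assay, at which 1 of the 3 values shown sits.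

Compound 4 `Cc1cc(Nc2cc(-c3ccccc3)[nH]n2)n2nc(SCC3CCCCC3)nc2n1` is not yet measured. It differs from compound 1 by cyclohexyl in place of 1-benzothiophen-3-yl on a saturated chain carbon bound to a sulfur. For the measured compounds named here, no measured pair shows the effect of trading an aromatic bicyclic group for a saturated ring at this place, so no step size is known. The change is expected to weaken inhibition by a modest step, a 2.0-fold higher number from compound 1 to compound 4 (0.31 log units; beyond the scatter), a little beyond the scatter. Compound 4 is thus estimated at 9000 nM in this assay, with a plausible range from 3000 nM to 27000 nM.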

Compound 4, half-maximal inhibitory concentration: > 50000 nM
Compound 4: a limit, no number; the forecaster's own chance of this, stated with the estimate: 15%; middle value at least 5.5-fold (0.74 log units) from the limit.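

For the compounds shown here, the exchange of 1-benzothiophen-3-yl for cyclohexyl on a saturated chain carbon bound to a sulfur is the only single-place change in this set, and it gives an at least 11-fold higher number from compound 1 to compound 4 (1.05 log units; beyond the scatter). This place is therefore not indifferent to the group it carries: with the rest of compound 1 kept, a non-aromatic ring of carbon only takes the read-out in this assay to the end of its range, and one pair supports no wider trend across groups at this place. Compound 4 gives a limit and not a number, so the step has a lower bound but no measured size: the limit of > 50000 nM in this assay, at which 2 of the 4 values shown sit.

From the compounds shown here alone, whether the difference follows the aromatic rings or the ring sulfur stays open, since the change removes both at once, and a naphthalen-1-ylmethyl or a plain benzyl on the sulfur of the same compound would separate the two. Also open, going by these compounds, is how a saturated ring carrying an amine, such as piperidin-4-ylmethyl, or a longer chain ending in cyclohexyl would read at this place.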